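Removing the amide substituent in a whole-animal series

The source may report more compounds than this note shows. Statements on the series, on what has been measured and on what is new or still open speak of the compounds shown alone.

Measured so far:
compound 1, `O=C(/C=C1\CCc2ccc(F)cc21)Nc1ccccc1`, 8 mg/kg
compound 2, `O=C(/C=C1\CCc2ccc(F)cc21)NC1CCCC1`, 14 mg/kg

Both compounds share the same core and differ only in what sits on the amide-type nitrogen. In a functional assay on the whole organism with Rattus norvegicus as the target (on this read-out higher numbers stand for an effect only at larger amounts of compound and lower numbers for an effect already at smaller amounts), compound 1 gives 8 mg/kg, and compound 2 gives 14 mg/kg. Within the data shown here, the single step between them, a 1.8-fold higher number from compound 1 to compound 2 (0.24 log units; within the scatter), did not move the number beyond the scatter, so the two compounds cannot be told apart; compound 2 merely carries the higher of the two numbers.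

Compound 3, `NC(=O)/C=C1\CCc2ccc(F)cc21`, goes one step further: hydrogen in place of cyclopentyl on an amide-type nitrogen. Among the measured compounds shown here, no measured step bears directly on this change; the only step on record swaps one ring for another on that nitrogen rather than removing the group altogether. That step was within the scatter, which gives little ground for predicting either direction. The ring is lost entirely here, and a primary amide is a larger departure than the ring swap, so some weakening is a plausible outcome, though not a certain one.

Compound 3 is therefore estimated at 22 mg/kg in this assay, with a range from 8 mg/kg to 60 mg/kg, an expected step of a 1.6-fold higher number from compound 2 to compound 3 (0.20 log units; within the scatter).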

Compound 3, dose for half-maximal effect: 21 mg/kg
Beside the measured number, compound 3's estimate is 1.0-fold (0.02 log units) above it, and the stated range covers the measured number.
By their numbers in this assay, from the lowest: compounds 1, 2 and 3 (each within the scatter of the next, the first and the last beyond it).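

In this assay, removing the ring from the amide-type nitrogen altogether gives a 1.5-fold higher number from compound 2 to compound 3 (0.18 log units; within the scatter), so at this position a cyclopentyl group and a bare hydrogen cannot be told apart. Hydrogen in place of phenyl gives a 2.6-fold higher number from compound 1 to compound 3 (0.42 log units; beyond the scatter) and is the first step on this nitrogen to clear the scatter, although only modestly, while compound 2 stays within the scatter of both compound 1 and compound 3. No other measurement here explains these numbers, so they show only how the dose shifts and not why.

The shown compounds place just three groups on this nitrogen, leaving open whether the gap between phenyl and hydrogen would hold up or widen with a benzyl group, a methyl group or a longer chain such as butyl. They also leave open whether a phenyl ring carrying a chlorine or a methoxy group would separate further from compound 3 in this whole-animal test.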